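The source may hold more compounds than are shown below. What is called first, only, known or untested is meant among the compounds shown, and "the series" means these compounds.

In a functional assay on PC-3 cells (Homo sapiens) for antiproliferative activity, read by MTT assay (a higher number here means a weaker inhibitor, a lower number a stronger inhibitor), compound 3 `Cc1cc(C)c(/C=N/Nc2ncc3c(n2)n(C2CCCC2)c(=O)c(=O)n3C)c(C)c1` gives 13900 nM, the lowest of the three numbers available, while compound 1 `Cc1cccc(/C=N/Nc2ncc3c(n2)n(C2CCCC2)c(=O)c(=O)n3C)c1` gives 53600 nM and compound 2 `Cn1c(=O)c(=O)n(C2CCCC2)c2nc(N/N=C/c3cccs3)ncc21` gives 75600 nM. The separation is real: the step of a 3.9-fold lower number from compound 1 to compound 3 (0.59 log units; beyond the scatter) and the step of a 5.4-fold lower number from compound 2 to compound 3 (0.74 log units; beyond the scatter) both lie beyond the scatter, whereas the step of a 1.4-fold higher number from compound 1 to compound 2 (0.15 log units; within the scatter) does not.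

Compound 4 `Cc1ccc(/C=N/Nc2ncc3c(n2)n(C2CCCC2)c(=O)c(=O)n3C)cc1C` has not yet been measured in this assay. It differs from compound 3 in one place: 3,4-dimethylphenyl in place of 2,4,6-trimethylphenyl on a carbon with a double bond to nitrogen. Going by the values given here, no measured step matches this exact exchange, but the two steps that bear on it both show that a 2,4,6-trimethylphenyl on this carbon gives a lower number than either a 3-methylphenyl or a thiophen-2-yl, by a modest margin in each case. Compound 4 carries a 3,4-dimethylphenyl, which shares one methyl with the 3-methylphenyl of compound 1 and keeps two of the three methyls of compound 3.

The step from compound 3 to compound 4 is therefore expected to go upward, by roughly a 2.2-fold higher number from compound 3 to compound 4 (0.33 log units; beyond the scatter), placing compound 4 between compound 3 and compound 1. Compound 4 is estimated to give 30000 nM in this assay, with a range of 12000 nM to 75000 nM.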

Compound 4, half-maximal inhibitory concentration: 39000 nM
Compound 4: the middle estimate sits 1.3-fold (0.11 log units) below what was measured, and the stated range covers the measured number.
By their numbers in this assay, from the lowest: compound 3; then compounds 4, 1 and 2 (each within the scatter of the next).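

In this assay, the step of a 2.8-fold higher number from compound 3 to compound 4 (0.45 log units; beyond the scatter) shows that on this carbon with a double bond to nitrogen, the low number of compound 3 does not carry over to every methyl-bearing phenyl, although 3,4-dimethylphenyl and 2,4,6-trimethylphenyl are both one six-membered aromatic ring of carbon only, with no hydrogen-bond donors or acceptors. The added methyl does not separate the new compound from its closest relative, as the step of a 1.4-fold lower number from compound 1 to compound 4 (0.14 log units; within the scatter) shows, and the exchange for thiophen-2-yl, the step of a 1.9-fold lower number from compound 2 to compound 4 (0.29 log units; within the scatter), does not separate them either, so compound 3 alone stands apart from the other three, each of its steps to them lying beyond the scatter. Nothing at hand explains why the 2,4,6-trimethylphenyl stands apart in this way.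

On these data alone, the separation therefore rests on compound 3 alone, and it remains open whether any other group on this carbon would reach its number. A methoxy group or an amine on the aromatic ring in place of a methyl is also untested among the compounds shown, so what such a group would do to the number remains unknown.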